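The compounds below may be only part of what the source reports. "The series", "measured", "known", "first", "only" and "open" are said of these compounds alone.

The measured compounds in a functional assay on HT-29 cells (Homo sapiens) for antiproliferative activity, read by MTT assay, with a stated time of 48 h (a higher number here means a weaker inhibitor, a lower number a stronger inhibitor), are:
compound 1, `O=C(/C=C\Nc1ccc(F)cc1)c1cn(-c2ccccc2)nc1-c1ccccc1`, 6870 nM;
compound 2, `O=C(/C=C\Nc1ccc(Cl)cc1)c1cn(-c2ccccc2)nc1-c1ccccc1`, 3610 nM;
compound 3, `COc1ccc(N/C=C\C(=O)c2cn(-c3ccccc3)nc2-c2ccccc2)cc1`, 1560 nM.

Among these three, compound 1 gives the highest number in this assay. Its nearest neighbour is compound 2, reached by a 1.9-fold lower number from compound 1 to compound 2 (0.28 log units; within the scatter); its furthest is compound 3, reached by a 4.4-fold lower number from compound 1 to compound 3 (0.64 log units; beyond the scatter). Between the other two stands a 2.3-fold lower number from compound 2 to compound 3 (0.36 log units; beyond the scatter).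

Compound 4, `O=C(/C=C\Nc1ccc(F)cc1)c1cn(-c2ccccc2)nc1-c1ccc(F)cc1`, differs from compound 1 by fluoro in place of hydrogen on an aromatic carbon. The fluoro enters an aromatic carbon of a six-membered aromatic ring of carbon only, para to a large group; cut one bond further out, the change reads phenyl to 4-fluorophenyl. All three measured steps exchange the substituent on the ring that carries the fluoro, chloro or methoxy in compounds 1 to 3, and leave the ring changed here untouched, so none of them bears directly on this step. They show only that a single small aromatic substituent moved the number by a modest amount at most. For a fluoro entering where hydrogen stood, no shift beyond the scatter is expected in this assay, in either direction, and the step is therefore estimated as a 1.1-fold lower number from compound 1 to compound 4 (0.06 log units; within the scatter). Compound 4 is expected to give about 6000 nM in this assay, within a range from 2500 nM to 15000 nM.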

Compound 4, half-maximal inhibitory concentration: 6500 nM
Compound 4: middle estimate off by 1.1-fold (0.03 log units), on the low side, and the stated range covers the measured number.
By their numbers in this assay, from the lowest: compound 3; then compounds 2, 4 and 1 (each within the scatter of the next).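

In this assay, fluoro in place of hydrogen on an aromatic carbon, para to a large group, gives a 1.1-fold lower number from compound 1 to compound 4 (0.02 log units; within the scatter), so the change from phenyl to 4-fluorophenyl does not separate these two compounds. For the compounds shown here, this is the first reading on this ring, since the steps among compounds 1, 2 and 3 all lay on the other aromatic ring and left this one untouched. At this position, then, hydrogen and fluoro cannot be told apart in this assay, though that holds for this one substituent alone and only with the fluoro on the other ring kept in place. Nothing in the material shown bears on the reason for this result.

The compounds shown leave open whether a different group at the same place, such as methoxy, chloro, an amine or a carboxylic acid, would move the number beyond the scatter, as methoxy in place of fluoro did on the other ring. They also leave open whether the 4-fluorophenyl would read the same way if methoxy stood on that other ring, as it does in compound 3.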